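The compounds below may be only part of what the source reports. "The series", "measured", "known", "first", "only" and "open" are said of these compounds alone.

Measured compounds:
- compound 1, `COc1ccc(C(=O)/C=C/c2ccc(OCc3cn(Cc4ccccc4F)nn3)cc2)cc1`, 32%
- compound 2, `COc1ccc(C(=O)/C=C/c2ccc(OCc3cn(Cc4cccc(F)c4)nn3)cc2)cc1`, 41%

In a functional assay on MCF7 cells (Homo sapiens) for inhibition, read by MTT assay, with a stated time of 48 h, tested at 10 uM (a higher number here means more inhibition of growth at the concentration tested, a lower number less inhibition of growth), compound 1 gives 32%, which is the lower of the two numbers recorded; the nearest neighbour is compound 2 with 41%, and the step of a number 9 percentage points higher from compound 1 to compound 2 (within the scatter) is within the scatter, so the two read as alike.

Compound 3, `O=C(/C=C/c1ccc(OCc2cn(Cc3ccccc3F)nn2)cc1)c1ccc([N+](=O)[O-])cc1`, has not yet been tested in this assay. It differs from compound 1 by nitro in place of methoxy on an aromatic carbon. Going by the values given here, the only measured step, a number 9 percentage points higher from compound 1 to compound 2 (within the scatter), concerns a different part of the molecule, the fluorophenyl on the saturated chain carbon bound to the aromatic nitrogen, and says nothing about the exchange at the carbonyl-bearing ring. Among the compounds with values here, no measured step therefore bears on this change, and no direction can be argued from the data.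

On that basis compound 3 is expected to land near compound 1, with an estimated step of a number 3 percentage points higher from compound 1 to compound 3 (within the scatter) that could fall either way, and an estimate of 35% with a range from 15% to 60%.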

Compound 3, percent growth inhibition at one concentration: 33%
Compound 3: the middle estimate sits 2 percentage points above what was measured, and the stated range covers the measured number.
By their numbers in this assay, from the lowest: compounds 1, 3 and 2 (each within the scatter of the next).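

Methoxy and nitro on this aromatic carbon, para to a large group, now have a direct comparison: in this assay the exchange on the 2-fluorophenyl background gives a number 1 percentage points higher from compound 1 to compound 3 (within the scatter) as the step. Going by these compounds alone, the earlier compounds spoke only to the fluorine on the benzyl-side ring, so this is the first reading at this position, and the 4-methoxyphenyl and 4-nitrophenyl compounds read as alike. No measurement on hand accounts for this likeness.

Still open, on these data alone, is whether an amine or a carboxylic acid at this position would also read alike, or whether a step beyond the scatter would appear. Also open, as far as these compounds go, is whether the nitro for methoxy exchange gives the same reading on the 3-fluorophenyl background of compound 2.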